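The source may report more compounds than this note shows. Statements on the series, on what has been measured and on what is new or still open speak of the compounds shown alone.

Compound 1 `CN(C)C(=O)c1cc2cnc(Nc3ccc(NC(=O)C4(C(=O)Nc5ccc(Cl)cc5)CC4)cc3)nc2n1C1CCCC1`: 22.8%
Compound 2 `CN(C)C(=O)c1cc2cnc(Nc3ccc(NC(=O)C4(C(=O)Nc5ccc(Br)cc5)CC4)cc3)nc2n1C1CCCC1`: 21.1%
Compound 3 `CN(C)C(=O)c1cc2cnc(Nc3ccc(NC(=O)C4(C(=O)Nc5cccc(C(F)(F)F)c5)CC4)cc3)nc2n1C1CCCC1`: 9.7%

All three compounds were read in a functional assay on T47D cells (Homo sapiens) for inhibition, read by CCK-8 assay, with a stated time of 72 h, tested at 1 uM; on this read-out higher numbers stand for more inhibition of growth at the one concentration tested and lower numbers for less inhibition of growth. Compound 3 stands lowest of the three, and its gap to each of the others lies beyond the scatter: a number 13.1 percentage points lower from compound 1 to compound 3 (beyond the scatter) and a number 11.4 percentage points lower from compound 2 to compound 3 (beyond the scatter).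

The next compound, compound 4 `CN(C)C(=O)c1cc2cnc(Nc3ccc(NC(=O)C4(C(=O)Nc5cccc(Br)c5)CC4)cc3)nc2n1C1CCCC1`, keeps the shared core and alters one group: bromo in place of trifluoromethyl on an aromatic carbon. Bromo takes the place of trifluoromethyl on an aromatic carbon, meta to a large group, so that 3-(trifluoromethyl)phenyl becomes 3-bromophenyl.

For the measured compounds named here, no measured step makes this exact exchange. The closest is a number 11.4 percentage points lower from compound 2 to compound 3 (beyond the scatter), but it alters both the group and its place, and the data do not separate the two. Compound 4 shares its bromo with compound 2 and its place on the ring with compound 3, so it may recover part of that modest step. The swap of bromo for chloro, a number 1.7 percentage points lower from compound 1 to compound 2 (within the scatter), stayed within the scatter and offers no sign of a large effect from the halogen itself. A small upward change is therefore expected, possibly no larger than the scatter, and the estimated step is a number 6.3 percentage points higher from compound 3 to compound 4 (within the scatter). For compound 4 the estimated value is 16%, with an expected range from 7% to 27%.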

Compound 4, percent growth inhibition at one concentration: 29.1%
Compound 4: the middle estimate sits 13.1 percentage points below what was measured; the whole stated range lies below it.
By their numbers in this assay, from the lowest: compound 3; then compounds 2, 1 and 4 (each within the scatter of the next).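

In this assay, the exchange of trifluoromethyl for bromo on an aromatic carbon, meta to a large group, gives a number 19.4 percentage points higher from compound 3 to compound 4 (beyond the scatter). For the compounds shown here, this separates what the earlier steps left joined: with the place held fixed, the group alone changes the reading by more than the scatter. Set against 4-bromophenyl, 3-bromophenyl gives a number 8 percentage points higher from compound 2 to compound 4 (within the scatter), and set against 4-chlorophenyl it gives a number 6.3 percentage points higher from compound 1 to compound 4 (within the scatter), so among these compounds the low reading goes with 3-(trifluoromethyl)phenyl and not with the place as such, although no measurement at hand explains why.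

The compounds shown leave open whether this follows from trifluoromethyl alone or would extend to other groups at this place, such as a methoxy group, a nitrile, a methyl group or an amine. They also leave open how the three halogen-bearing compounds would separate at other concentrations, since each reading comes from a single concentration and those readings lie within the scatter of their neighbours.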